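The source may report more compounds than this note shows. Statements on the series, on what has been measured and on what is new or still open speak of the compounds shown alone.

Of the compounds shown here, three sharing one core have been tested in a functional assay on HT-29 cells (Homo sapiens) for antiproliferative activity, read by sulforhodamine B assay, with a stated time of 72 h; a higher number here means a weaker inhibitor, a lower number a stronger inhibitor. Compound 3 `NC(=S)N/N=C/c1ccc2ccccc2n1` gives 100000 nM in this assay. Compound 2 `N#Cc1ccc(NC(=S)N/N=C/c2ccc3ccccc3n2)cc1` gives 15600 nM. Compound 1 `COc1ccccc1NC(=S)N/N=C/c1ccc2ccccc2n1` reaches only a limit of this assay, at > 100000 nM. Of the two real numbers, compound 3 stands highest; the step of a 6.4-fold higher number from compound 2 to compound 3 (0.81 log units; beyond the scatter) was modest, while the step of a number no higher from compound 1 to compound 3 (the limit leaves the size open) cannot be sized because compound 1 sits at the limit of > 100000 nM in this assay, at which 1 of the 3 values shown sits.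

Compound 4 `COc1cccc(NC(=S)N/N=C/c2ccc3ccccc3n2)c1` differs from compound 3 by 3-methoxyphenyl in place of hydrogen on an amide-type nitrogen. Adding a 4-cyanophenyl lowered the number modestly in the step of a 6.4-fold higher number from compound 2 to compound 3 (0.81 log units; beyond the scatter), whereas the 2-methoxyphenyl case of compound 1 remains unsized. Compound 4 is therefore expected near 50000 nM, between 12000 nM and 120000 nM. The expected step is a 2.0-fold lower number from compound 3 to compound 4 (0.30 log units; within the scatter).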

Compound 4, half-maximal inhibitory concentration: 82400 nM
The estimate for compound 4 lay 1.6-fold (0.22 log units) below the measured number, within the range that was stated.
By their numbers in this assay, from the lowest: compound 2; then compounds 4 and 3 (each within the scatter of the next).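

Putting 3-methoxyphenyl on the amide-type nitrogen in place of hydrogen gives only a 1.2-fold lower number from compound 3 to compound 4 (0.08 log units; within the scatter), so carrying an aryl ring there does not by itself bring a gain. Compound 2 stands apart from this result, with a 5.3-fold higher number from compound 2 to compound 4 (0.72 log units; beyond the scatter). The comparison with the other methoxyphenyl compound reads an at least 1.2-fold lower number from compound 1 to compound 4 (0.08 log units; that floor lies within the scatter), and its size stays open as compound 1 is held at a limit of the assay: the limit of > 100000 nM in this assay, at which 1 of the 4 values shown sits.

The compounds shown leave open whether the nitrile itself matters on that ring. An unsubstituted phenyl or a 4-aminophenyl would help to separate the ring from its substituent.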